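A 3,4-dichlorophenyl swap on compound 1

The source may hold more compounds than are shown below. What is called first, only, known or untested is meant among the compounds shown, and "the series" means these compounds.

Three related compounds have been tested in a functional assay on SN12C cells (Homo sapiens) for inhibition, read by sulforhodamine B assay, with a stated time of 48 h; on this read-out higher numbers stand for weaker inhibition of growth and lower numbers for stronger inhibition of growth. Compound 1 `O=C(Nc1cccc(-n2cc(-c3ccncc3)c(-c3ccc(Cl)c(O)c3)n2)c1)Nc1cccc(C(F)(F)F)c1` gives only a limit (> 32500 nM) and not a number. Compound 3 `COc1cc(-c2nn(-c3cccc(NC(=O)c4cccc(C(F)(F)F)c4)c3)cc2-c2ccncc2)ccc1Cl` also gives only a limit (> 50000 nM) and not a number. Compound 2 `COc1cc(-c2nn(-c3cccc(NC(=O)Nc4cc(C(F)(F)F)cc(C(F)(F)F)c4)c3)cc2-c2ccncc2)ccc1Cl` does give a number (3320 nM) in the same test. As far as these compounds go, compound 1 therefore stands with compound 3 among the two results that are limits, so its true value is unknown.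

Compound 4 `O=C(Nc1cccc(-n2cc(-c3ccncc3)c(-c3ccc(Cl)c(O)c3)n2)c1)Nc1ccc(Cl)c(Cl)c1` has 3,4-dichlorophenyl in place of 3-(trifluoromethyl)phenyl on an amide-type nitrogen. For the measured compounds named here, no measured pair of compounds shows this exact change, so any forecast is loose. In this assay a modest step toward stronger inhibition of growth is expected, though it may stay within the usual scatter. That expectation leans on compound 2 (3320 nM), which shows that a number can be reached in this series. The expected change is an at least 1.4-fold lower number from compound 1 to compound 4 (0.16 log units; that floor lies within the scatter) on this estimate. For compound 4 the estimated value is 22000 nM with an expected range from 6000 nM to 60000 nM in this test.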

Compound 4, concentration for total growth inhibition: > 32500 nM
Compound 4 ended at the assay's limit; the forecaster's own chance of this, stated with the estimate: 50%; at least 1.4-fold (0.16 log units) between middle value and limit.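

In this assay compound 4 gives > 32500 nM, which is a limit and not a number. Compound 1 also stands at a limit, so the step between compound 1 and compound 4 cannot be read. As far as these compounds go, whether 3,4-dichlorophenyl or 3-(trifluoromethyl)phenyl on the amide-type nitrogen gives stronger inhibition of growth remains open.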